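The compounds below may be only part of what the source reports. "The series", "measured", "known", "first", "only" and "open" are said of these compounds alone.

Compound 1 `CS(=O)(=O)c1cccc(-c2ccc3ncc(-c4ccc(S(C)(=O)=O)nc4)n3n2)c1` is the starting point of this step. In a physicochemical assay for solubility, at pH 6.5 (a lower number here means a less soluble compound, a higher number a more soluble compound), compound 1 returns only a limit, < 5000 nM, and no number places it within the series. Compound 2 `CS(=O)(=O)c1ccc(-c2cnc3ccc(-c4cncc(C(F)(F)F)c4)nn23)cc1` likewise returns only a limit in this assay, < 5000 nM. Among the measured compounds shown here, both readings sit at the same boundary the limit of < 5000 nM in this assay, at which 2 of the 2 values shown sit, and no measured step separates them. Compound 3 `CS(=O)(=O)c1cccc(-c2ccc3ncc(-c4ccc(N)nc4)n3n2)c1` differs from compound 1 by amino in place of methylsulfonyl on an aromatic carbon. For the measured compounds named here, no measured step covers this change; the step of an at least 3.0-fold higher number from compound 1 to compound 3 (0.47 log units; beyond the scatter) is expected to run upward, beyond the scatter. Compound 3 is estimated at 15000 nM, between 3000 nM and 60000 nM.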

Compound 3, solubility: < 5000 nM
Compound 3: only a limit was reported; the forecaster's own chance of this, stated with the estimate: 35%; middle value at least 3.0-fold (0.47 log units) away from the limit.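

Compound 3 gives only a limit in this assay, < 5000 nM, so no step from compound 1 to compound 3 can be read: the limit of < 5000 nM in this assay, at which 3 of the 3 values shown sit.

The compounds shown leave open where compound 1, compound 2 and compound 3 lie beneath that limit, and whether amino in place of methylsulfonyl shifts the read-out at all.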